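The source may hold more compounds than are shown below. What is called first, only, known or untested is meant among the compounds shown, and "the series" means these compounds.

Measured compounds:
compound 1, `C=CCc1ccc(OC)c(-c2ccn(-c3ccccc3)n2)c1`: 8920 nM
compound 2, `C=CCc1ccc(OC)c(-c2ccn(Cc3ccccc3)n2)c1`: 36000 nM
compound 3, `CCCc1ccc(O)c(-c2ccn(-c3ccccc3)n2)c1`: 109000 nM

All three were tested in a functional assay on BV-2 cells (Mus musculus) for inhibition, read by Griess assay, with a stated time of 24 h; on this read-out lower numbers stand for stronger inhibition and higher numbers for weaker inhibition. Compound 1 and compound 2 share a core and differ by one change, (benzyl in place of phenyl on an aromatic nitrogen); that change gave a 4.0-fold higher number from compound 1 to compound 2 (0.61 log units; beyond the scatter). Compound 3 carries a different core, and the difference between the two cores is not broken down here. Among the three, compound 3 gives the highest number in this assay.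

Compound 4, `CCCc1ccc(O)c(-c2ccn(Cc3ccccc3)n2)c1`, is not yet measured. It differs from compound 3 by benzyl in place of phenyl on an aromatic nitrogen, the same change that separates compound 1 from compound 2. He expects the step from compound 3 to compound 4 to resemble the earlier one, because of a 4.0-fold higher number from compound 1 to compound 2 (0.61 log units; beyond the scatter) on the other core, giving an estimated 3.5-fold higher number from compound 3 to compound 4 (0.54 log units; beyond the scatter). For compound 4 he therefore estimates 380000 nM in this assay, between 130000 nM and 1100000 nM.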

Compound 4, half-maximal inhibitory concentration: 116000 nM
For compound 4 the middle estimate is 3.3-fold (0.52 log units) above the measured one; measured number below the stated range.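

In this assay, benzyl in place of phenyl on an aromatic nitrogen gave a 1.1-fold higher number from compound 3 to compound 4 (0.03 log units; within the scatter), so on this core the change made no difference that can be told from scatter. The size of the step thus did not carry over from one core to the other: the same change on two cores in this assay, a 4.0-fold higher number (0.61 log units; beyond the scatter) from compound 1 to compound 2 and a 1.1-fold higher number (0.03 log units; within the scatter) from compound 3 to compound 4, 3.8-fold (0.58 log units) apart, beyond the scatter of two such steps. This shows that the step seen on the core of compound 1 cannot be assumed for the core of compound 3, but two pairs do not show which difference between the cores matters or how the change would behave on a further core.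

The compounds shown leave open how a longer chain ending in phenyl, an amine or a carboxylic acid would read on that nitrogen in this assay.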